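This account rests on a few compounds, and the source may have more. Where it says the series, first, only, none or still open, it means among the compounds named here.

Cytotoxicity in a functional assay on MT4 cells (Homo sapiens) for cytotoxicity, read by MTT assay (on this read-out lower numbers stand for higher toxicity in this test and higher numbers for lower toxicity in this test), for the three measured members of the series. Compound 1 `CCOc1ccc(CSc2nc(O)c(C)c(Cc3c(Cl)cccc3Cl)n2)cc1` gives > 58000 nM, which is a limit of the assay and not a number. Compound 2 `Cc1c(O)nc(SCc2ccccc2)nc1Cc1c(Cl)cccc1Cl` gives > 64000 nM, again a limit. Compound 3 `Cc1c(O)nc(SCc2cccc(Cl)c2)nc1Cc1c(Cl)cccc1Cl` gives > 59000 nM, also a limit. All three readings thus sit at limits: the limit of > 58000 nM in this assay, at which 1 of the 3 values shown sits, (the limit of > 59000 nM in this assay, at which 1 of the 3 values shown sits), (the limit of > 64000 nM in this assay, at which 1 of the 3 values shown sits). Compound 3 therefore stands at a limit, and the two further values shown are limits as well, so the steps a step that the two limits leave unreadable from compound 1 to compound 2, a step that the two limits leave unreadable from compound 1 to compound 3 and a step that the two limits leave unreadable from compound 2 to compound 3 carry no readable size.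

Compound 4 `Cc1c(O)nc(SCc2ccc(F)cc2)nc1Cc1c(Cl)cccc1Cl` differs from compound 3 by 4-fluorophenyl in place of 3-chlorophenyl on a saturated chain carbon bound to a sulfur. The measured steps that touch the same place, on the saturated chain carbon bound to a sulfur, are the ones ending at compound 3, and both are unreadable between limits, so no size or direction can be taken from them. a step that the limit leaves unreadable from compound 3 to compound 4 is accordingly expected to lie within the scatter. Compound 4 is expected to give 80000 nM in this assay, within a range of 40000 nM to 200000 nM, and most likely to be reported only as a limit.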

Compound 4, half-maximal cytotoxic concentration: > 61000 nM
Compound 4: no number, only a limit (the forecaster's own chance of this, stated with the estimate: 85%); the middle value lies beyond the limit too.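

No new step can be read: compound 4 stands at a limit in this assay, as do compound 1, compound 2 and compound 3, and its steps to those three carry no readable size. The compounds shown leave open where any actual half-maximal cytotoxic concentration lies, and whether the benzyl substituents differ at all.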